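Ethyl in Place of Phenyl on a Ring Amine Nitrogen

The source may report more compounds than this note shows. Statements on the series, on what has been measured and on what is new or still open speak of the compounds shown alone.

Of the compounds shown here, three sharing one core have been measured in a functional assay on IMR-32 cells (Homo sapiens) for antiproliferative activity, read by sulforhodamine B assay, with a stated time of 48 h (a lower number here means a stronger inhibitor, a higher number a weaker inhibitor), and their numbers lie close together. Compound 1 `COc1ccc(C[C@@H](O)/C=C/C=C/C(=O)N2CCCCC2)cc1OC` stands at 11000 nM on this scale. Compound 2 `COc1ccc(C[C@@H](O)/C=C/C=C/C(=O)N2CCN(C)CC2)cc1OC` stands at 18900 nM on the same scale. Compound 3 `COc1ccc(C[C@@H](O)/C=C/C=C/C(=O)N2CCN(c3ccccc3)CC2)cc1OC` stands at 9430 nM and sits within the usual scatter of both others, which leaves no firm order among the three.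

Next comes compound 4 `CCN1CCN(C(=O)/C=C/C=C/[C@H](O)Cc2ccc(OC)c(OC)c2)CC1` with the change ethyl in place of phenyl on an amine nitrogen in a ring and in words this is ethyl in place of phenyl on an amine nitrogen in a ring. For the measured compounds named here, two measured steps bear on it. Putting 4-methylpiperazin-1-yl in place of piperidin-1-yl gave a 1.7-fold higher number from compound 1 to compound 2 (0.24 log units; within the scatter) as its result. Putting phenyl in place of methyl, at the nitrogen that changes now, gave a 2.0-fold lower number from compound 2 to compound 3 (0.30 log units; within the scatter) as its result. Both are small, and the second is the closer guide. The ethyl of compound 4 has no ring, like the methyl of compound 2 at 18900 nM and a small rise toward that number is therefore expected in this assay with no step beyond the scatter. The estimated move is a 1.6-fold higher number from compound 3 to compound 4 (0.20 log units; within the scatter) on this reasoning. For compound 4 the expected value is 15000 nM with an estimated range from 8000 nM to 28000 nM as a working expectation.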

Compound 4, half-maximal inhibitory concentration: 10800 nM
Compound 4: the middle estimate sits 1.4-fold (0.14 log units) above what was measured; low and high end bracket the measured number.
By their numbers in this assay, from the lowest: compounds 3, 4, 1 and 2 (each within the scatter of the next).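

In this assay, the change on this amine nitrogen from phenyl, with 6 heavy atoms and an aromatic ring, to ethyl, with 2 heavy atoms and no ring, gives a 1.1-fold higher number from compound 3 to compound 4 (0.06 log units; within the scatter), so removing the aromatic ring here does not shift the number measurably. The small alkyl groups behave alike too: extending the methyl by one carbon gives a 1.8-fold lower number from compound 2 to compound 4 (0.24 log units; within the scatter), while 4-ethylpiperazin-1-yl in place of piperidin-1-yl on the carbonyl carbon gives a 1.0-fold lower number from compound 1 to compound 4 (0.01 log units; within the scatter). Phenyl, methyl and ethyl on this nitrogen are therefore not told apart by this assay, and no available evidence explains why these changes have so little effect.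

As far as these compounds go, it remains open whether any group at this nitrogen can move the number beyond the scatter, for example a longer chain ending in a carboxylic acid or a primary amine. A benzyl group would test whether an aromatic ring held one carbon further from the nitrogen behaves any differently from the phenyl of compound 3.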